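Replacing a Benzyl Arm with a Dimethoxyphenyl Group

The source may hold more compounds than are shown below. What is called first, only, known or untested is meant among the compounds shown, and "the series" means these compounds.

The account concerns two compounds sharing a fused bicyclic core and one proposed variant. Compound 1 `C=C(Br)C(=O)Nc1cccc(-c2cn3nc(Cc4cccc(OC)c4)sc3n2)c1` was tested in a functional assay on L1210 cells (Mus musculus) for inhibition, read by cell counting, with a stated time of 2 days (a lower number here means a stronger inhibitor, a higher number a weaker inhibitor), and gave 2000 nM. Compound 2 `COc1ccc(Cc2nn3cc(-c4cccc(N)c4)nc3s2)cc1` gave 227000 nM in this assay, so compound 1 stands as the lower of the two numbers, and the gap between them lies well beyond the scatter of repeated measurements.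

The new compound 3 `C=C(Br)C(=O)Nc1cccc(-c2cn3nc(-c4ccc(OC)c(OC)c4)sc3n2)c1` keeps everything in compound 1 except one substituent: 3,4-dimethoxyphenyl in place of 3-methoxybenzyl on an aromatic carbon. Within the data shown here, no measured pair in this set isolates that kind of exchange, so there is no comparable step to lean on.

With only the two numbers above as background, a modest step is expected, if any, and its direction cannot be set from the data; the estimate for compound 3 is 3000 nM, between 600 nM and 15000 nM. The step that this estimate implies, a 1.5-fold higher number from compound 1 to compound 3 (0.18 log units; within the scatter), is expected to stay close to the scatter of this assay, with a wide range reflecting the absence of a guiding comparison.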

Compound 3, half-maximal inhibitory concentration: 42 nM
For compound 3 the middle estimate is 71-fold (1.85 log units) above the measured one; measured number outside the range, below it.
By their numbers in this assay, from the lowest: compound 3; then compound 1; then compound 2.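

In this assay, putting 3,4-dimethoxyphenyl in place of 3-methoxybenzyl on this aromatic carbon of the five-membered ring gives a 48-fold lower number from compound 1 to compound 3 (1.68 log units; beyond the scatter), which shows that a change at this single position, with the rest of compound 1 kept, can move the number far beyond the scatter. The earlier compounds shown here could not show this, since compound 1 and compound 2 differ in more than one place. The exchange also alters two things at once, removing the benzyl carbon so that the aromatic ring sits directly on the core and adding a second methoxy group, and nothing in hand bears on why the number falls or which of these alterations matters.

The compounds shown leave open whether the gain would survive with a plain phenyl or a phenyl carrying a single methoxy group, or whether a benzyl arm carrying both methoxy groups would do the same. They also leave open how an amine or a carboxylic acid on this aromatic ring would fare in place of the methoxy groups.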